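A few compounds are considered here, and "the series" means these few. Any claim that something is new, unique, unknown or untested is made for them only; others in the source may bear on it.

Compound 1 `Cc1n[nH]c2ccc(-c3nc4cnc(N5CCN(C)CC5)cn4c3Nc3ccc(Cl)cc3F)cc12` was tested in a functional assay on MV4-11 cells (Homo sapiens) for inhibition, with a stated time of 120 h (a higher number here means a weaker inhibitor, a lower number a stronger inhibitor), where compound 1 gives 10400 nM. Compound 2 `COc1ccc(Nc2c(-c3ccc4[nH]nc(C)c4c3)nc3cnc(N4CCN(C)CC4)cn23)cc1OC` shares the core of compound 1 but carries a 3,4-dimethoxyphenyl on the aromatic nitrogen; in this assay compound 2 is reported as "not determined" (no result reported), so compound 2 stands on no number at all. Compound 3 `Cc1n[nH]c2ccc(-c3nc4cnc(N5CCN(C)CC5)cn4c3Nc3ccc(F)c(Cl)c3)cc12` is the next member: it differs from compound 2 by 3-chloro-4-fluorophenyl in place of 3,4-dimethoxyphenyl on a nitrogen on an aromatic ring. Since compound 2 offers no value, no size or direction of step from compound 2 to compound 3 can be drawn from the data. Among the compounds with values here, the only anchor is compound 1, which carries a differently substituted halophenyl on the same nitrogen and gives 10400 nM in this assay. On that basis compound 3 is expected to be a weak inhibitor in this assay, estimated at 8000 nM with a range of 2000 nM to 30000 nM.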

Compound 3, half-maximal inhibitory concentration: 2850 nM
Estimate against measurement, compound 3: 2.8-fold (0.45 log units) above; the measured number falls inside the stated range.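

In this assay, within the data shown here, the 3-chloro-4-fluorophenyl in place of 4-chloro-2-fluorophenyl on the aromatic nitrogen gives a 3.6-fold lower number from compound 1 to compound 3 (0.56 log units; beyond the scatter), the first readable comparison at this position, and it shows that with the shared core unchanged, rearranging the halogens on this phenyl alone moves the number beyond the scatter. The step from compound 2 to compound 3 cannot be read, so the 3,4-dimethoxyphenyl remains unplaced against either halophenyl. Nothing measured here bears on why the number moves.

Both halogens sit differently in the two compounds, so the step cannot be assigned to either one alone. On these data alone, how a plain phenyl, a phenyl with a single chlorine or a pyridine would read on this nitrogen remains open.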